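A larger hydroxylated ring on the aromatic nitrogen

The source may report more compounds than this note shows. Statements on the series, on what has been measured and on what is new or still open speak of the compounds shown alone.

Compound 1 `O=C1c2c[n+]([O-])c3ccccc3c2C(=O)c2c1c1ccccc1n2Cc1cn([C@H]2C[C@H](O)[C@@H](CO)O2)nn1` carries a 4-hydroxy-5-(hydroxymethyl)oxolan-2-yl group on an aromatic nitrogen of a five-membered aromatic ring with 3 nitrogen, and in a functional assay on SH-SY5Y cells (Homo sapiens) for cytotoxicity, read by MTT assay, with a stated time of 72 h (on this read-out lower numbers stand for stronger inhibition and higher numbers for weaker inhibition), compound 1 gives 620 nM. That is the lowest of the three numbers recorded so far. Compound 2 `O=C1c2c[n+]([O-])c3ccccc3c2C(=O)c2[nH]c3ccccc3c21`, which bears hydrogen on the aromatic nitrogen of its core, gives in this assay 1380 nM, a gap from compound 1 that lies beyond the scatter. Compound 3 `O=C1c2c[n+]([O-])c3ccccc3c2C(=O)c2c1c1ccccc1n2CCCCN1CCNCC1` gives in this assay 1240 nM, which is within the scatter of compound 1. Within the data shown here, the single measured step, a 1.1-fold lower number from compound 2 to compound 3 (0.05 log units; within the scatter), is itself within the scatter. Compound 4 `O=C1c2c[n+]([O-])c3ccccc3c2C(=O)c2c1c1ccccc1n2Cc1cn([C@@H]2O[C@H](CO)[C@@H](O)[C@H](O)[C@H]2O)nn1` differs from compound 1 in one place: 3,4,5-trihydroxy-6-(hydroxymethyl)oxan-2-yl in place of 4-hydroxy-5-(hydroxymethyl)oxolan-2-yl on an aromatic nitrogen. Among the measured compounds shown here, no measured step touches this position, and the one step that exists concerns a different aromatic nitrogen and was small. The expectation is therefore a step of a 1.2-fold higher number from compound 1 to compound 4 (0.08 log units; within the scatter), that is, nothing beyond the scatter. Compound 4 is estimated at 750 nM, with a range from 300 nM to 1900 nM.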

Compound 4, half-maximal inhibitory concentration: 880 nM
Compound 4: middle estimate off by 1.2-fold (0.07 log units), on the low side; the measured number falls inside the stated range.
By their numbers in this assay, from the lowest: compounds 1, 4, 3 and 2 (each within the scatter of the next, the first and the last beyond it).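

At this position, the first step read here is a 1.4-fold higher number from compound 1 to compound 4 (0.15 log units; within the scatter) in this assay, on replacing 4-hydroxy-5-(hydroxymethyl)oxolan-2-yl with 3,4,5-trihydroxy-6-(hydroxymethyl)oxan-2-yl. A five-membered non-aromatic ring thus gives way to a six-membered one, with the count of heavy atoms rising, hydrogen-bond donors from 2 to 4 and defined stereocentres from 3 to 5, and the number does not move beyond the scatter. No measurement bears on why this is so.

The compounds shown leave open whether ring size and the added hydroxyl groups would each have the same outcome, as the two change together in this step. They also leave open whether an amine or a carboxylic acid on this ring, or a plain butyl chain in its place, would shift the number beyond the scatter.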